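The source may report more compounds than this note shows. Statements on the series, on what has been measured and on what is new or still open speak of the compounds shown alone.

Measured compounds:
compound 1 `N#C/C(=C\c1ccc([N+](=O)[O-])cc1)C(=O)c1c[nH]c2ccccc12` with 47000 nM
compound 2 `N#C/C(=C\c1c(F)c(F)c(F)c(F)c1F)C(=O)c1c[nH]c2ccccc12` with 35000 nM
compound 3 `COc1ccc(CNC(=O)/C(C#N)=C/c2ccco2)cc1` with 32000 nM

All three values come from a functional assay on NCI-H460 cells (Homo sapiens) for inhibition, read by MTT assay, with a stated time of 72 h; on this read-out lower numbers stand for stronger inhibition of growth and higher numbers for weaker inhibition of growth. Compound 3 shows the lowest of the three numbers, but its gap to compound 2 and its gap to compound 1 each lie within the scatter, so no order among the three can be read.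

Compound 4 `COc1ccc(CNC(=O)/C(C#N)=C/c2ccc(-c3ccccc3)o2)cc1` is not yet measured. It differs from compound 3 by phenyl in place of hydrogen on an aromatic carbon, next to the ring oxygen. Among the compounds with values here, no measured pair shows this change, so its size cannot be read from the numbers at hand. For compound 4 the expected step is a 1.6-fold lower number from compound 3 to compound 4 (0.20 log units; within the scatter), small, toward lower numbers at most, and possibly none beyond the scatter. The estimate for compound 4 in this assay is 20000 nM, with a range from 6000 nM to 60000 nM.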

Compound 4, concentration for 50% growth inhibition: > 100000 nM
Compound 4: a limit, no number; the forecaster's own chance of this, stated with the estimate: 10%; at least 5.0-fold (0.69 log units) between middle value and limit.
By their numbers in this assay, from the lowest: compounds 3, 2 and 1 (each within the scatter of the next). At a limit, above all of these: compound 4.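

In this assay compound 4 gives > 100000 nM, which is a limit and not a number. Phenyl in place of hydrogen on an aromatic carbon, next to the ring oxygen, gives an at least 3.1-fold higher number from compound 3 to compound 4 (0.49 log units; beyond the scatter), the first step in the series that can be read beyond the scatter. Within the data shown here, this position is therefore not indifferent to change, which the earlier compounds could not show, and the step has a lower bound only.

Open, as far as these compounds go, is whether a methyl group, a chlorine atom or an amine at this carbon would stay within the scatter of compound 3. Also open, from the compounds shown here alone, is whether a phenyl ring carrying a carboxylic acid would follow compound 4.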